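This account rests on a few compounds, and the source may have more. Where it says the series, first, only, none or still open, it means among the compounds named here.

Values in a functional assay on A549 cells (Homo sapiens) for antiproliferative activity, read by MTT assay, with a stated time of 24 h; on this read-out higher numbers stand for weaker inhibition and lower numbers for stronger inhibition:
Compound 1 `O=C(NNc1ccc(F)cc1)c1cccc(NS(=O)(=O)c2cnc(O)nc2O)c1` - > 20000 nM (a limit, not a number)
Compound 2 `O=C(NNc1ccccc1F)c1ccccc1NS(=O)(=O)c1cnc(O)nc1O` - 9610 nM
Compound 3 `O=C(NNC(=O)c1cccc(NS(=O)(=O)c2cnc(O)nc2O)c1)c1ccc(F)cc1` - > 20000 nM (a limit, not a number)

Within the data shown here, compound 2 gives 9610 nM, the only true number in the set. The other two results sit at one limit, (the limit of > 20000 nM in this assay, at which 2 of the 3 values shown sit), so compound 2 is the sole anchor for the next step.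

Compound 4 `O=C(NNC(=O)c1ccccc1NS(=O)(=O)c1cnc(O)nc1O)c1ccccc1Cl` is still to be measured in this assay. The change from compound 2 is (2-chlorophenyl)carbonyl in place of 2-fluorophenyl on an amine nitrogen.

Among the measured compounds shown here, the one measured step of a similar kind is a step that the two limits leave unreadable from compound 1 to compound 3, and it supplies no size to carry over. Compound 3 carries (4-fluorophenyl)carbonyl on an amine nitrogen and stays at > 20000 nM, which is a limit. Compound 1 lacks that carbonyl and shows > 20000 nM, also a limit, so the carbonyl cannot be singled out from these data.

The direction therefore rests on weak evidence, with a modest shift toward weaker inhibition expected and a result at the limit quite possible. The expected change is a 1.5-fold higher number from compound 2 to compound 4 (0.16 log units; within the scatter), an estimate with wide uncertainty. For compound 4 the estimated value is 14000 nM, with an expected range of 6000 nM to 30000 nM.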

Compound 4, half-maximal inhibitory concentration: 5290 nM
Beside the measured number, compound 4's estimate is 2.6-fold (0.42 log units) above it; the whole stated range lies above it.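

In this assay, (2-chlorophenyl)carbonyl in place of 2-fluorophenyl on this amine nitrogen gives a 1.8-fold lower number from compound 2 to compound 4 (0.26 log units; within the scatter), the first readable size for a change of this kind; the step from compound 1 to compound 3 cannot be read, since both of its ends are limits. On the core shared with compound 2, a carbonyl on this amine nitrogen therefore still allows a true number, and compound 4 stays off the limit that marks the rest of the set: the limit of > 20000 nM in this assay, at which 2 of the 4 values shown sit. The added carbonyl and the exchange of fluorine for chlorine arrive together in this one step, so neither can be credited separately, and the step lies within the scatter, which leaves compound 2 and compound 4 level as read here.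

From the compounds shown here alone, how the carbonyl and the halogen each act alone remains open, a question that (2-fluorophenyl)carbonyl or a plain 2-chlorophenyl on the same nitrogen would address. Also open, going by these compounds, is whether a group without an aromatic ring, such as acetyl, or a benzoyl bearing a carboxylic acid, would keep a true number at this place.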